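Furan to oxazole on the anilide-free nitrogen side chain

The source may report more compounds than this note shows. Statements on the series, on what has been measured and on what is new or still open speak of the compounds shown alone.

In a functional assay (aorta) with Rattus norvegicus as the target (a lower number here means a stronger inhibitor, a higher number a weaker inhibitor), compound 1 `CC1(C)Oc2ccc(C#N)cc2[C@H](Nc2ccccc2)[C@H]1O` gives 1200 nM. Compound 2 `CC1(C)Oc2ccc(C#N)cc2[C@H](N(CC#N)c2ccccc2)[C@H]1O`, bearing cyanomethyl on the nitrogen, gives 59000 nM, which is a 49-fold higher number from compound 1 to compound 2 (1.69 log units; beyond the scatter). Compound 3 `CC1(C)Oc2ccc(C#N)cc2[C@H](N(Cc2ccco2)c2ccccc2)[C@H]1O`, bearing (furan-2-yl)methyl, gives 12000 nM, which is a 10-fold higher number from compound 1 to compound 3 (1.00 log units; beyond the scatter), so it stands between the other two. Compound 4 `CC1(C)Oc2ccc(C#N)cc2[C@H](N(Cc2ncco2)c2ccccc2)[C@H]1O` differs from it by 1,3-oxazol-2-yl in place of furan-2-yl on a saturated chain carbon bound to a nitrogen on an aromatic ring, with 1,3-oxazol-2-yl in place of furan-2-yl on a saturated chain carbon bound to a nitrogen on an aromatic ring. The closest measured change at that carbon, cyano to furan-2-yl, is modest, a 4.9-fold lower number from compound 2 to compound 3 (0.69 log units; beyond the scatter). Exchanging one five-membered aromatic ring for another should move the number less, so a small rise is expected, a 1.3-fold higher number from compound 3 to compound 4 (0.12 log units; within the scatter). The estimate for compound 4 is 16000 nM, within 5000 nM to 50000 nM.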

Compound 4, half-maximal inhibitory concentration: > 30000 nM
Compound 4 ended at the assay's limit (the forecaster's own chance of this, stated with the estimate: 5%); middle value at least 1.8-fold (0.27 log units) away from the limit.
By their numbers in this assay, from the lowest: compound 1; then compound 3; then compound 2.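

Compound 4 stands at a limit of this assay, not at a number: the limit of > 30000 nM in this assay, at which 1 of the 4 values shown sits. Even an exchange of one five-membered aromatic ring for another matters at this carbon, with an at least 2.5-fold higher number from compound 3 to compound 4 (0.39 log units; beyond the scatter), so the added ring nitrogen of 1,3-oxazol-2-yl does not leave the number unchanged. All three substituents on the nitrogen now raise the number over hydrogen, the newest with an at least 25-fold higher number from compound 1 to compound 4 (1.39 log units; beyond the scatter), while the step between compound 2 and compound 4 cannot be read. Going by these compounds, whether an amine, a carboxylic acid or a longer chain at this nitrogen would bring the number back towards that of compound 1 remains open.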